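Replacing oxan-4-yl with 4-hydroxycyclohexyl on the shared core

The source may hold more compounds than are shown below. What is called first, only, known or untested is meant among the compounds shown, and "the series" means these compounds.

Going by the values given here, in a functional assay on NCI-H1975 cells (Homo sapiens) for antiproliferative activity, read by MTT assay, with a stated time of 72 h (a lower number here means a stronger inhibitor, a higher number a weaker inhibitor), compound 1 (`CN1CCN(c2ccc(Nc3ncc4nc(Sc5ccccc5)n(C5CCOCC5)c4n3)cc2)CC1`) gives 2260 nM as the lower of the two numbers so far, and compound 2 (`CN(C)C1CCN(c2ccc(Nc3ncc4nc(Sc5ccccc5)n(C5CCOCC5)c4n3)cc2)CC1`) gives 4990 nM in the same test. Among the compounds with values here, compound 3 (`CN1CCN(c2ccc(Nc3ncc4nc(Sc5ccccc5)n([C@H]5CC[C@H](O)CC5)c4n3)cc2)CC1`) differs from compound 1 at one place, on an aromatic nitrogen of a five-membered aromatic ring: 4-hydroxycyclohexyl in place of oxan-4-yl on an aromatic nitrogen (the group on that nitrogen is the only change). Within the data shown here, the single measured step, a 2.2-fold higher number from compound 1 to compound 2 (0.34 log units; beyond the scatter) on an aromatic carbon, lies elsewhere in the molecule. Among the measured compounds shown here, it therefore shows only how far one swap has moved the number, and no measured step touches the group on that nitrogen. In this assay the expected step is a 1.1-fold higher number from compound 1 to compound 3 (0.04 log units; within the scatter) with no direction favoured by the data. Compound 3 is expected at 2500 nM with 800 nM to 7500 nM as the estimated range.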

Compound 3, half-maximal inhibitory concentration: 1320 nM
For compound 3 the middle estimate is 1.9-fold (0.28 log units) above the measured one; measured number inside the range.
By their numbers in this assay, from the lowest: compounds 3 and 1 (each within the scatter of the next); then compound 2.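

Going by these compounds alone, this is the first measured step at the group on the aromatic nitrogen of the five-membered ring, and in this assay it reads a 1.7-fold lower number from compound 1 to compound 3 (0.23 log units; within the scatter). Oxan-4-yl, with 0 hydrogen-bond donors and a hetero atom in its ring, and 4-hydroxycyclohexyl, with 1 hydrogen-bond donor and a ring of carbon only, thus cannot be told apart in this test on the shared core. No measurement at hand bears on why the two groups read alike.

The compounds shown leave open how an amine or a carboxylic acid in place of the hydroxyl on the cyclohexyl ring, or an open alkyl chain on that nitrogen, would read. They also leave open whether a 2.2-fold higher number from compound 1 to compound 2 (0.34 log units; beyond the scatter) would recur with 4-hydroxycyclohexyl on the nitrogen.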